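A few compounds are considered here, and "the series" means these few. Any claim that something is new, unique, unknown or untested is made for them only; others in the source may bear on it.

Compound 1 `COc1ccc(/C=C\C(=O)O)c(OCc2cn(-c3ccc(NC(=O)c4ccccc4)cc3)nn2)c1CC=C(C)C` gives 23300 nM in a functional assay on T47D cells (Homo sapiens) for cytotoxicity, read by MTT assay, with a stated time of 24 h; on this read-out higher numbers stand for weaker inhibition and lower numbers for stronger inhibition. Compound 2 `COc1ccc(/C=C\C(=O)O)c(OCc2cn(-c3ccccc3F)nn2)c1CC=C(C)C` gives 11000 nM. Compound 3 `COc1ccc(/C=C\C(=O)O)c(OCc2cn(-c3ccccc3)nn2)c1CC=C(C)C` gives 34100 nM.

Compound 3 thus shows the highest number of the three. Its gap to compound 1 lies within the scatter, a 1.5-fold higher number from compound 1 to compound 3 (0.17 log units; within the scatter), whereas the loss of the fluoro was a modest step, a 3.1-fold higher number from compound 2 to compound 3 (0.49 log units; beyond the scatter).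

Compound 4 `COc1ccc(/C=C\C(=O)O)c(OCc2cn(-c3nc4ccccc4s3)nn2)c1CC=C(C)C` differs from compound 3 by 1,3-benzothiazol-2-yl in place of phenyl on an aromatic nitrogen. Within the data shown here, no measured step replaces that phenyl with another ring; the two steps only show that a fluoro on it lowered the number modestly and a benzamido left it within the scatter. A modest shift in either direction is therefore plausible, with a slight lean toward a lower number. Compound 4 is expected at 20000 nM, between 6000 nM and 55000 nM, which means a 1.7-fold lower number from compound 3 to compound 4 (0.23 log units; within the scatter).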

Compound 4, half-maximal inhibitory concentration: 17200 nM
The estimate for compound 4 lay 1.2-fold (0.07 log units) above the measured number; the range from low to high includes it.
By their numbers in this assay, from the lowest: compounds 2, 4, 1 and 3 (each within the scatter of the next, the first and the last beyond it).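

The aromatic nitrogen that carried phenyl can also carry a two-ring group. In this assay the swap to 1,3-benzothiazol-2-yl stays within the scatter (a 2.0-fold lower number from compound 3 to compound 4 (0.30 log units; within the scatter)), and so does the comparison with the 2-fluorophenyl compound (a 1.6-fold higher number from compound 2 to compound 4 (0.19 log units; within the scatter)). No measurement here explains these numbers.

Going by these compounds, whether the nitrogen and sulfur of 1,3-benzothiazol-2-yl matter, or only its two rings, stays open, and a naphthyl group at this place would separate the two. On these data alone, the effect of an amine or a methoxy group on the benzothiazole's six-membered ring also remains unknown.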